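Methoxyphenyl Isomers in a Bis(trifluoromethyl)sulfonamide Series

This account rests on a few compounds, and the source may have more. Where it says the series, first, only, none or still open, it means among the compounds named here.

Measured compounds:
compound 1, `O=S(=O)(NCCCNCc1cccc2ccccc12)c1cc(C(F)(F)F)cc(C(F)(F)F)c1`: 3100 nM
compound 2, `COc1ccccc1CNCCCNS(=O)(=O)c1cc(C(F)(F)F)cc(C(F)(F)F)c1`: 1500 nM

Both compounds were tested in a functional assay on A2780 cells (Homo sapiens) for inhibition, read by MTT assay, with a stated time of 72 h; on this read-out higher numbers stand for weaker inhibition of growth and lower numbers for stronger inhibition of growth. Compound 1 gives 3100 nM, while compound 2 gives 1500 nM, the lowest of the two numbers; its nearest neighbour is compound 1, and the step of a 2.1-fold lower number from compound 1 to compound 2 (0.32 log units; beyond the scatter) lies beyond the scatter.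

Compound 3, `COc1ccc(CNCCCNS(=O)(=O)c2cc(C(F)(F)F)cc(C(F)(F)F)c2)cc1`, has not yet been measured. It differs from compound 2 as follows: 4-methoxyphenyl in place of 2-methoxyphenyl on a saturated chain carbon bound to an amine nitrogen. The two compounds share every atom and differ only in how the methoxy substituent and the ring are joined.

Of the measured steps, only a 2.1-fold lower number from compound 1 to compound 2 (0.32 log units; beyond the scatter) exists, and it exchanges a whole ring system rather than relocating a single substituent, so it says little about the change from compound 2 to compound 3. Among the measured compounds shown here, with no step of the same kind on record, no movement beyond the scatter is expected. Compound 3 is therefore estimated at 1800 nM, with a range of 700 nM to 4500 nM, which corresponds to an expected step of a 1.2-fold higher number from compound 2 to compound 3 (0.08 log units; within the scatter).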

Compound 3, concentration for 50% growth inhibition: 1700 nM
Compound 3: the middle estimate sits 1.1-fold (0.02 log units) above what was measured; measured number inside the range.
By their numbers in this assay, from the lowest: compounds 2, 3 and 1 (each within the scatter of the next, the first and the last beyond it).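

In this assay, moving the methoxy group, with 4-methoxyphenyl in place of 2-methoxyphenyl on a saturated chain carbon bound to an amine nitrogen, gives a 1.1-fold higher number from compound 2 to compound 3 (0.05 log units; within the scatter), so the two isomers cannot be told apart on this read-out. Among the compounds shown here, this is the first relocation of a single substituent, and here it leaves the number within the scatter. Against naphthalen-1-yl, the picture is less clear-cut: the exchange for 4-methoxyphenyl gives a 1.8-fold lower number from compound 1 to compound 3 (0.26 log units; within the scatter), whereas the exchange for 2-methoxyphenyl gave a 2.1-fold lower number from compound 1 to compound 2 (0.32 log units; beyond the scatter), so only compound 2 is separated from compound 1 by more than the scatter, even though compound 2 and compound 3 are themselves indistinguishable. No independent evidence bears on this result.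

The compounds shown leave open whether the same indifference to placement would hold for a group other than methoxy, such as 4-chlorophenyl or 4-hydroxyphenyl, in this place. They also do not tell how the numbers would respond to a longer chain between the amine nitrogen and the sulfonamide.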